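The source may report more compounds than this note shows. Statements on the series, on what has been measured and on what is new or still open speak of the compounds shown alone.

Measured compounds:
Compound 1, `FC(F)(F)c1ccc(-c2nn(-c3ccccc3)cc2CNc2ccc(Cl)cc2)cc1`: 10000 nM
Compound 2, `Cc1ccc(NCc2cn(-c3ccccc3)nc2-c2ccc(Cl)cc2)cc1`: > 100000 nM

Both were tested in an ADME assay on Vero 76 cells (Chlorocebus sabaeus) for cytotoxicity, read by MTT assay, with a stated time of 96 h; a higher number here means that more compound is tolerated, a lower number that less compound is tolerated. In this assay compound 1 gives 10000 nM. For compound 2 the result in this assay is not a number but a limit, > 100000 nM, so compound 2 stands at the limit of > 100000 nM in this assay, at which 1 of the 2 values shown sits, and its true value is known only to lie beyond that bound. No pair of these compounds differs in just one place, so the two values show only that compound 1 gave a number while compound 2 did not.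

Compound 3, `Cc1ccc(NCc2cn(-c3ccccc3)nc2-c2ccccc2)cc1`, has not been measured yet. It follows from compound 2 by the change (hydrogen in place of chloro on an aromatic carbon), the 4-chlorophenyl becoming a phenyl. Within the data shown here, nothing among the measured compounds tells how this change affects this assay, so the expected step in this assay is a number no higher from compound 2 to compound 3 (the limit leaves the size open), nothing beyond the scatter. Compound 3 is expected at 100000 nM, between 40000 nM and 300000 nM in this assay, and quite possibly only a limit will again be reported.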

Compound 3, half-maximal cytotoxic concentration: > 100000 nM
Compound 3 ended at the assay's limit; the forecaster's own chance of this, stated with the estimate: 65%; the middle value lies on the limit itself.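

No step can be read from compound 2 to compound 3, since each gives only a limit rather than a number in this assay: the limit of > 100000 nM in this assay, at which 2 of the 3 values shown sit. From the compounds shown here alone, how far the change from 4-chlorophenyl to phenyl moves the tolerated concentration in this assay remains open.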